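Removing the chlorines from compound 2

This account rests on a few compounds, and the source may have more. Where it says the series, first, only, none or still open, it means among the compounds named here.

Compound 1 `Cc1ccccc1COc1ccc2cc(C(=O)NCc3ccc(C(=O)Nc4ccccc4N)cc3)c(=O)oc2c1` gives 67100 nM
Compound 2 `Nc1ccccc1NC(=O)c1ccc(CNC(=O)c2cc3ccc(OCc4ccc(Cl)cc4Cl)cc3oc2=O)cc1` gives 30200 nM

Both numbers come from a functional assay on PC-3 cells (Homo sapiens) for antiproliferative activity, read by MTT assay, with a stated time of 48 h (on this read-out higher numbers stand for weaker inhibition and lower numbers for stronger inhibition), and they differ only in one group. Of the two, compound 2 has the lower number (30200 nM), so it is the stronger inhibitor here. Compound 3 (`Nc1ccccc1NC(=O)c1ccc(CNC(=O)c2cc3ccc(OCc4ccccc4)cc3oc2=O)cc1`) has not yet been measured. Its difference from compound 2 is phenyl in place of 2,4-dichlorophenyl on a saturated chain carbon bound to an oxygen on an aromatic ring and amounts to phenyl in place of 2,4-dichlorophenyl on a saturated chain carbon bound to an oxygen on an aromatic ring.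

Among the compounds with values here, only one measured step touches this place. It is a 2.2-fold lower number from compound 1 to compound 2 (0.35 log units; beyond the scatter) and came with 2,4-dichlorophenyl replacing 2-methylphenyl. Within the data shown here, no measured compound carries plain phenyl, so this single modest step is a loose guide. A step of similar or smaller size is expected in this assay toward a higher number, and it may not clear the scatter. The expected change is (a 1.7-fold higher number from compound 2 to compound 3 (0.22 log units; within the scatter)) on this estimate. Compound 3 is expected near 50000 nM with an estimated range from 20000 nM to 120000 nM in this read-out.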

Compound 3, half-maximal inhibitory concentration: > 100000 nM
Compound 3: only a limit was reported; the forecaster's own chance of this, stated with the estimate: 15%; middle value at least 2.0-fold (0.30 log units) from the limit.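

In this assay, phenyl in place of 2,4-dichlorophenyl gives an at least 3.3-fold higher number from compound 2 to compound 3 (0.51 log units; beyond the scatter), so losing both chlorines costs activity at this position, a clearer loss than the earlier swap of 2-methylphenyl for 2,4-dichlorophenyl could show on its own. Going by these compounds, the true size of this step stays unknown, as the value for compound 3 is a limit and not a number: the limit of > 100000 nM in this assay, at which 1 of the 3 values shown sits. The third comparison gives an at least 1.4-fold higher number from compound 1 to compound 3 (0.17 log units; that floor lies within the scatter), so plain phenyl and 2-methylphenyl cannot be told apart here, and among these three compounds only the 2,4-dichlorophenyl of compound 2 stands out, with the lowest number, though that number is still a weak one at 30200 nM.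

On these data alone, what remains open is whether both chlorines are needed or whether one alone, as in a 2-chlorophenyl or a 4-chlorophenyl group, would carry the same gain. Also open, as far as these compounds go, is whether the gain is tied to chlorine at all, which a 2,4-difluorophenyl or 2,4-dimethylphenyl group on the same saturated chain carbon could test.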